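Swapping the aryl amine substituent in a weakly antiproliferative series

The source may hold more compounds than are shown below. What is called first, only, known or untested is meant among the compounds shown, and "the series" means these compounds.

The measured compounds and their numbers in a functional assay on U2OS cells (Homo sapiens) for antiproliferative activity, read by MTT assay, with a stated time of 72 h; a lower number here means a stronger inhibitor, a higher number a weaker inhibitor:
compound 1 `CCCCOC1=C(C(=O)c2ccccc2)C(c2ccc(Br)cc2)N(CCCn2ccnc2)C1=O`: 32400 nM
compound 2 `CCOc1ccc(NC2=C(C(=O)c3ccccc3)C(c3ccc(Br)cc3)N(CCCn3ccnc3)C2=O)cc1`: 26200 nM
compound 3 `O=C(C1=C(Nc2ccc(F)cc2)C(=O)N(CCCn2ccnc2)C1c1ccc(Br)cc1)c1ccccc1`: 30000 nM

All three numbers lie close together. The step of a 1.2-fold lower number from compound 1 to compound 2 (0.09 log units; within the scatter) and the step of a 1.1-fold lower number from compound 1 to compound 3 (0.03 log units; within the scatter) are both within the scatter, as is the step of a 1.1-fold higher number from compound 2 to compound 3 (0.06 log units; within the scatter). For the measured compounds named here, compound 3 therefore stands second highest of the three, but no compound can be set apart from the others on these numbers.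

Compound 4 `O=C(C1=C(Nc2ccccc2Br)C(=O)N(CCCn2ccnc2)C1c1ccc(Br)cc1)c1ccccc1` differs from compound 3 in one place: 2-bromophenyl in place of 4-fluorophenyl on an amine nitrogen. Going by the values given here, the only measured step that touches the same aryl ring is the step of a 1.1-fold higher number from compound 2 to compound 3 (0.06 log units; within the scatter), which was within the scatter; the two steps from compound 1 show that even replacing the whole aryl amine by butoxy left the number within the scatter. No change so far has moved this assay, so the step of no change at the digits printed from compound 3 to compound 4 (within the scatter) is expected to be small, with no direction beyond the scatter. Compound 4 is therefore estimated at 30000 nM in this assay, in a range from 12000 nM to 75000 nM.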

Compound 4, half-maximal inhibitory concentration: 16900 nM
Compound 4: middle estimate off by 1.8-fold (0.25 log units), on the high side; measured number inside the range.
By their numbers in this assay, from the lowest: compounds 4, 2, 3 and 1 (each within the scatter of the next).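

Compound 4 carries bromine on the aryl ring of the amine, where the earlier aryl amines carry fluorine or ethoxy, and this change still does not set it apart in this assay: 2-bromophenyl in place of 4-fluorophenyl gives a 1.8-fold lower number from compound 3 to compound 4 (0.25 log units; within the scatter) and in place of 4-ethoxyphenyl gives a 1.6-fold lower number from compound 2 to compound 4 (0.19 log units; within the scatter) while (2-bromophenyl)amino in place of butoxy gives a 1.9-fold lower number from compound 1 to compound 4 (0.28 log units; within the scatter). All four compounds therefore remain within the scatter of one another, so none can be singled out. Nothing available here offers a reason for these numbers.

From compound 3 to compound 4 both the halogen and its number in the group name differ, so the two changes cannot be told apart. From the compounds shown here alone, it also stays open whether a carboxylic acid or an amine on this aryl ring would move the number beyond the scatter.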